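The compounds below may be only part of what the source reports. "The series", "measured", "known", "first", "only" and "open" are said of these compounds alone.

Going by the values given here, compound 1 `Cc1cc2c(cc1Cc1ccc(C(=O)NCC3CCCCC3)o1)C(C)(C)CCC2(C)C` gives 1550 nM in an assay on isolated protein for binding affinity to Gonadotropin-releasing hormone receptor (Rattus norvegicus) (on this read-out higher numbers stand for weaker inhibition and lower numbers for stronger inhibition), the higher of the two numbers known so far; compound 2 `Cc1cc2c(cc1Cc1ccc(C(=O)NCc3ccccc3)o1)C(C)(C)CCC2(C)C` gives 240 nM. Among the compounds with values here, the only measured step, a 6.5-fold lower number from compound 1 to compound 2 (0.81 log units; beyond the scatter), swaps the ring on the saturated chain carbon and says nothing about substitution on the cyclohexyl ring itself. Compound 3 `Cc1cc2c(cc1Cc1ccc(C(=O)NCC3CCC(CNCc4c(C)noc4C)CC3)o1)C(C)(C)CCC2(C)C` carries (((3,5-dimethyl-1,2-oxazol-4-yl)methyl)amino)methyl in place of hydrogen on a saturated ring carbon. Within the data shown here, no measured pair bears on this change, so the expected step of a 1.9-fold lower number from compound 1 to compound 3 (0.29 log units; within the scatter) is small and uncertain in either direction. Compound 3 is estimated at 800 nM, within 150 nM to 4000 nM.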

Compound 3, inhibition constant: 1200 nM
Beside the measured number, compound 3's estimate is 1.5-fold (0.18 log units) below it; the range from low to high includes it.
By their numbers in this assay, from the lowest: compound 2; then compounds 3 and 1 (each within the scatter of the next).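

The saturated ring carbon, three ring bonds from the ring atom that bears a large group, takes (((3,5-dimethyl-1,2-oxazol-4-yl)methyl)amino)methyl with a 1.3-fold lower number from compound 1 to compound 3 (0.11 log units; within the scatter), so the two numbers cannot be told apart. Going by these compounds alone, this is the first reading on substitution of the cyclohexyl ring, and a group of this size there brings no step beyond the scatter. No outside evidence bears on this result.

From the compounds shown here alone, whether a smaller group at this carbon, such as a primary amine or a carboxylic acid, reads the same stays open. Also open, going by these compounds, is how the cyclohexyl ring carrying this group compares with the phenyl ring of compound 2.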